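This account rests on a few compounds, and the source may have more. Where it says the series, first, only, none or still open, it means among the compounds named here.

Measured so far in a functional assay on MDA-MB-231 cells (Homo sapiens) for antiproliferative activity, read by XTT assay, with a stated time of 72 h; on this read-out lower numbers stand for stronger inhibition and higher numbers for weaker inhibition:
- compound 1 `COc1ccc(-c2cc3ccccc3nc2/C=C/C(=O)c2ccc(O)cc2)cc1` gives 6350 nM
- compound 2 `COc1ccc(-c2cc3ccccc3nc2/C=C/C(=O)c2ccc(OC)c(OC)c2)cc1` gives 4790 nM

Compound 2 holds the lower of the two numbers, but the gap to compound 1 is within the scatter, so the two are not separated.

Compound 3 `COc1ccc(-c2cc3ccccc3nc2/C=C/C(=O)c2ccc(N)cc2)cc1` differs from compound 2 in one place: 4-aminophenyl in place of 3,4-dimethoxyphenyl on a carbonyl carbon. Within the data shown here, the only step that touches this carbonyl-bound aryl is a 1.3-fold lower number from compound 1 to compound 2 (0.12 log units; within the scatter), and it was within the scatter. Nothing here points to a change beyond the scatter on this assay, so a flat step is expected, a 1.0-fold higher number from compound 2 to compound 3 (0.02 log units; within the scatter).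

Compound 3 is estimated at 5000 nM in this assay, with a range from 2000 nM to 12500 nM.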

Compound 3, half-maximal inhibitory concentration: 7510 nM
Compound 3: middle estimate off by 1.5-fold (0.18 log units), on the low side; the measured number falls inside the stated range.
By their numbers in this assay, from the lowest: compounds 2, 1 and 3 (each within the scatter of the next).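

In this assay, the carbonyl-bound aryl tolerates 4-aminophenyl in place of 3,4-dimethoxyphenyl, with a 1.6-fold higher number from compound 2 to compound 3 (0.20 log units; within the scatter). Amino in place of hydroxy on an aromatic carbon also gives only a 1.2-fold higher number from compound 1 to compound 3 (0.07 log units; within the scatter), so a nitrogen-bearing substituent on this aryl leaves all three compounds unseparated. No measured evidence bears on these results.

From the compounds shown here alone, whether a carboxylic acid, an amide or a longer chain on this aryl would move the number beyond the scatter remains open. The shared core is the same in all three compounds, so they say nothing about changes there.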